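Lengthening the acyl chain at the assay limit

This account rests on a few compounds, and the source may have more. Where it says the series, first, only, none or still open, it means among the compounds named here.

Measured in a functional assay on CCRF-CEM cells (Homo sapiens) for cytotoxicity (on this read-out lower numbers stand for higher toxicity in this test and higher numbers for lower toxicity in this test), both values being limits:
compound 1 `CC(=O)Nc1nc(N)nc2c1ncn2[C@H]1CO[C@@H](CO)O1` gives > 100000 nM
compound 2 `CCCC(=O)Nc1nc(N)nc2c1ncn2[C@H]1CO[C@@H](CO)O1` gives > 100000 nM

Compound 2 stands only at a limit, > 100000 nM. Compound 3 `CCCCCC(=O)Nc1nc(N)nc2c1ncn2[C@H]1CO[C@@H](CO)O1` carries ethyl in place of hydrogen on a saturated chain carbon, three bonds along the chain from a carbonyl carbon, which also reads propyl to pentyl. Going by the values given here, the only measured step of the same ethyl-for-hydrogen kind is a step that the two limits leave unreadable from compound 1 to compound 2, and the limit of > 100000 nM in this assay, at which 2 of the 2 values shown sit, gives the whole picture so far. No step beyond the scatter is therefore expected in this assay, and the estimated a number no higher from compound 2 to compound 3 (the limit leaves the size open) is correspondingly small. Compound 3 is expected at 100000 nM, with an estimated range of 40000 nM to 200000 nM, and most likely as a limit again.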

Compound 3, half-maximal cytotoxic concentration: > 100000 nM
Compound 3 was reported as a limit; the forecaster's own chance of this, stated with the estimate: 80%; the middle value sits exactly at the limit.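

No step can be read among compound 1, compound 2 and compound 3, which all stand at a limit: the limit of > 100000 nM in this assay, at which 3 of the 3 values shown sit.

Whether lengthening the acyl chain changes the read-out at all remains open, as none of these compounds gives a value that is more than a limit.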